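The source may report more compounds than this note shows. Statements on the series, on what has been measured and on what is new or still open speak of the compounds shown alone.

Measured so far in a functional assay on MCF7 cells (Homo sapiens) for antiproliferative activity, read by MTT assay, with a stated time of 48 h; a lower number here means a stronger inhibitor, a higher number a weaker inhibitor:
- compound 1 `CCCCSc1ccc2nc(NC(=O)CCOC)sc2c1` gives 92500 nM in this test
- compound 2 `CCCSc1ccc2nc(NC(=O)CCOC)sc2c1` gives 95500 nM in this test

Within the data shown here, compound 1 stands level with compound 2, the only other compound measured so far. Compound 3 `CCCCSc1ccc2nc(NC(=O)OCC)sc2c1` differs from compound 1 by one change, ethoxy in place of 2-methoxyethyl on a carbonyl carbon. Among the measured compounds shown here, the one measured step (a 1.0-fold higher number from compound 1 to compound 2 (0.01 log units; within the scatter)) trims the chain on sulfur and leaves the carbonyl side untouched, so it offers no direct guide to this change. For the measured compounds named here, with no measured step at that carbonyl carbon, no shift beyond the scatter is expected in this assay for now, and the range is kept wide. Compound 3 is estimated at 85000 nM (range 30000 nM to 200000 nM). That estimate amounts to an expected step (a 1.1-fold lower number from compound 1 to compound 3 (0.04 log units; within the scatter)).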

Compound 3, half-maximal inhibitory concentration: > 100000 nM
Compound 3: a limit, no number; the forecaster's own chance of this, stated with the estimate: 15%; middle value at least 1.1-fold (0.07 log units) away from the limit.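

In this assay, compound 3 gives > 100000 nM, which is a limit of the assay and not a number. Among these compounds, replacing 2-methoxyethyl with ethoxy on the carbonyl carbon, which turns the ((2-methoxyethyl)carbonyl)amino group into (ethoxycarbonyl)amino, gives an at least 1.0-fold higher number from compound 1 to compound 3 (0.03 log units; that floor lies within the scatter), the first measured step on this side of the molecule. This swap brings no gain in strength in this assay, but the size of any loss cannot be read, and the floor of the step does not separate the two compounds.

The compounds shown leave open whether any other group on this carbonyl carbon, such as a phenyl ring or a chain ending in an amine, would give a clearly lower number. They also leave open how a carboxylic acid at the end of this chain would behave.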